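The source may hold more compounds than are shown below. What is called first, only, known or untested is meant among the compounds shown, and "the series" means these compounds.

Measured so far:
compound 1 `O=C(O)CCc1ccc(C#CC2CCCC2)cc1` — 94%
compound 2 `C/C=C(\C)C#Cc1ccc(CCC(=O)O)c(F)c1` — 97%

Both were run in a functional assay on 1321-N1 cells for agonist activity at Free fatty acid receptor 1 (Homo sapiens), read by calcium flux, with a stated time of 0.4 s; a lower number here means a smaller maximal response, a higher number a larger maximal response. Compound 1 reaches 94% and compound 2 reaches 97%; the two numbers lie within the scatter of each other, so nothing separates them in maximal response. Compound 2 therefore stands level with compound 1, and neither measured compound falls short of a near-full response.

Compound 3 `C=C(C)C#Cc1ccc(CCC(=O)O)c(F)c1` has not yet been run in this assay. It differs from compound 2 in one place: 1-methylethenyl in place of 1-methylprop-1-en-1-yl on a triple-bonded carbon. The group on the triple-bonded carbon becomes the smaller 1-methylethenyl while keeping its double bond outside aromatic rings. Because compound 2 reaches 97% and compound 1 reaches 94%, no step beyond the scatter is expected in this assay for compound 3, in either direction. Compound 3 is expected to give 93% (range 80% to 104%). The estimated step of a number 4 percentage points lower from compound 2 to compound 3 (within the scatter) is expected to stay within the scatter.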

Compound 3, largest response reached (reported as efficacy), in percent of the reference or control that the assay uses: 106%
The estimate for compound 3 lay 13 percentage points below the measured number, and the stated range ends below it.
By their numbers in this assay, from the lowest: compounds 1, 2 and 3 (each within the scatter of the next, the first and the last beyond it).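

In this assay, 1-methylethenyl in place of 1-methylprop-1-en-1-yl on a triple-bonded carbon gives a number 9 percentage points higher from compound 2 to compound 3 (within the scatter), so this exchange leaves the maximal response intact. The group on the triple-bonded carbon can therefore be cut back to 1-methylethenyl, with its double bond outside aromatic rings kept, and the series still reaches a full response; a single pair cannot show how far this tolerance extends. Nothing on hand gives a reason for this result.

Open, going by these compounds, is whether the same triple-bonded carbon accepts a group without the double bond, such as tert-butyl, or one carrying a hydroxyl or an amine, and still gives a full response. Also open, on these data alone, is how this exchange affects potency, as the read-out here gives only the largest response reached.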